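The source may hold more compounds than are shown below. What is called first, only, known or untested is meant among the compounds shown, and "the series" means these compounds.

Compound 1 `CCCN(CCC)c1cc(C)nc2c(-c3ncc(C)cc3N)c(C)nn12` gives 40 nM in an assay on isolated protein for binding affinity to corticotropin-releasing factor receptor 1 (Homo sapiens); on this read-out lower numbers stand for stronger inhibition and higher numbers for weaker inhibition. In this assay compound 2 `CCCN(CCC)c1cc(C)nc2c(-c3ncc(C)cc3N=O)c(C)nn12` is reported only as > 10000 nM, which is a limit of the assay and not a number. The step of an at least 250-fold higher number from compound 1 to compound 2 (2.39 log units; beyond the scatter) is the only measured one, and the limit of > 10000 nM in this assay, at which 1 of the 2 values shown sits, marks where compound 2 stands. Compound 3 `CCCN(CCC)c1cc(C)nc2c(-c3ncc(C)cc3O)c(C)nn12` differs from compound 2 by one oxygen atom in place of a group of 2 heavy atoms (1 nitrogen, 1 oxygen; no ring), on an aromatic carbon, the hydroxy entering on an aromatic carbon of a six-membered aromatic ring with 1 nitrogen, ortho to a large group. That measured step moves away from a single small group toward the two-atom group and ends at the limit, so for the present step it gives a direction but no firm size: the hydroxy of compound 3 resembles the amino of compound 1 in being a single atom with a hydrogen-bond donor. Compound 3 is therefore expected to show a large fall in the number, an at least 40-fold lower number from compound 2 to compound 3 (1.60 log units; beyond the scatter). The expected value for compound 3 is 250 nM, within 40 nM to 3000 nM.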

Compound 3, inhibition constant: > 10000 nM
Compound 3: only a limit was reported; the forecaster's own chance of this, stated with the estimate: 15%; at least 40-fold (1.60 log units) between middle value and limit.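

In this assay compound 3 is reported as > 10000 nM, which is a limit of the assay and not a number. Hydroxy in place of amino on this aromatic carbon gives an at least 250-fold higher number from compound 1 to compound 3 (2.39 log units; beyond the scatter), so a hydroxy, which also counts a hydrogen-bond donor, does not keep the level of compound 1 at this position. Both values for the step between compound 2 and compound 3 are limits, so that step cannot be read, and compound 1 remains the only compound here with a measured number: the limit of > 10000 nM in this assay, at which 2 of the 3 values shown sit.

On these data alone, how far compound 2 and compound 3 lie from each other remains open. Also open, as far as these compounds go, is whether the response at this position follows the nitrogen atom of the amino group or its hydrogens, a question that methylamino, dimethylamino or acetamido on the same carbon would address.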